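The source may hold more compounds than are shown below. What is called first, only, known or untested is meant among the compounds shown, and "the series" means these compounds.

In a physicochemical assay for lipophilicity, read by LC-MS (on this read-out lower numbers stand for lower lipophilicity and higher numbers for higher lipophilicity), compound 1 `FC(F)(F)c1cccc(N[C@H]2CC[C@@H](Nc3ccnc(C(F)(F)F)n3)CC2)c1` reads > 5.3, which is a limit of the assay and not a number. Going by the values given here, compound 2 `CSc1nnc2ccc(N[C@H]3CC[C@@H](Nc4ccnc(C(F)(F)F)n4)CC3)nn12` gives 2.8, the only true number so far, so it has no measured neighbour to be ranked against. Compound 3 `Nc1nnc2ccc(N[C@H]3CC[C@@H](Nc4ccnc(C(F)(F)F)n4)CC3)nn12` carries amino in place of methylsulfanyl on an aromatic carbon. Among the compounds with values here, no measured pair of compounds shows this change, so the expectation rests on the structural change alone. The expected step is a number 0.90 log units lower from compound 2 to compound 3 (beyond the scatter), toward lower numbers in this assay and beyond the scatter. Compound 3 is estimated at 1.9, with an expected range of 1.4 to 2.4.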

Compound 3, distribution coefficient: 1.4
Compound 3: middle estimate off by 0.50 log units, on the high side; measured number inside the range.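

Amino in place of methylsulfanyl gives the first readable step at this position, on an aromatic carbon between two ring nitrogen atoms: in this assay it is a number 1.40 log units lower from compound 2 to compound 3 (beyond the scatter), so this carbon clearly affects the read-out. Compound 1 cannot be set against this step, because its reading is a limit of the assay and not a number: the limit of > 5.3 in this assay, at which 1 of the 3 values shown sits.

This single pair cannot show whether the step follows the loss of sulfur or the arrival of the amino group. Going by these compounds, how a methoxy group or a longer amine would read at this carbon stays open.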